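A few compounds are considered here, and "the series" means these few. Any claim that something is new, unique, unknown or untested is made for them only; others in the source may bear on it.

Among the compounds with values here, compound 2 `Cc1ccccc1NC(=O)NCC1(c2ccccc2)CCCCC1` gives 640 nM in an assay on microsomes from intestine for inhibition of acyl-CoA:cholesterol acyltransferase (Oryctolagus cuniculus) (on this read-out lower numbers stand for stronger inhibition and higher numbers for weaker inhibition), the higher of the two numbers measured so far; compound 1 `COc1ccccc1NC(=O)NCC1(c2ccccc2)CCCCC1` gives 270 nM. Within the data shown here, the only measured step is a 2.4-fold higher number from compound 1 to compound 2 (0.37 log units; beyond the scatter). Compound 3 `COc1cccc(NC(=O)NCC2(c3ccccc3)CCCCC2)c1` differs from compound 2 by 3-methoxyphenyl in place of 2-methylphenyl on an amide-type nitrogen. This brings back a methoxy group, though as 3-methoxyphenyl rather than the 2-methoxyphenyl of compound 1, so the measured step bears on it only in part. In this assay the expected step is a 1.8-fold lower number from compound 2 to compound 3 (0.26 log units; within the scatter), a move that may well stay within the scatter. The estimate for compound 3 is 350 nM, with a range from 120 nM to 1000 nM.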

Compound 3, half-maximal inhibitory concentration: 2500 nM
Compound 3: the middle estimate sits 7.1-fold (0.85 log units) below what was measured; measured number above the stated range.
By their numbers in this assay, from the lowest: compound 1; then compound 2; then compound 3.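

Placing the methoxy group differently matters in this assay: 3-methoxyphenyl in place of 2-methoxyphenyl gives a 9.3-fold higher number from compound 1 to compound 3 (0.97 log units; beyond the scatter), so the group's mere presence does not secure the lower number of compound 1. Replacing 2-methylphenyl with 3-methoxyphenyl also costs activity, with a 3.9-fold higher number from compound 2 to compound 3 (0.59 log units; beyond the scatter), and among these compounds both with a 2-substituted phenyl give lower numbers than compound 3. No evidence is available to explain this result. Still open, going by these compounds, is whether 3-methylphenyl would fall in the same way as 3-methoxyphenyl. Unsubstituted phenyl and 4-methoxyphenyl would show how much any substituent, or its placement, contributes.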